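Fluorine removal on the benzyl amide of a T-type series

The source may hold more compounds than are shown below. What is called first, only, known or untested is meant among the compounds shown, and "the series" means these compounds.

Measured compounds:
compound 1 `O=C(CC1c2ccccc2N=C(SCCCCCN2CCCC2)N1c1ccc(-c2ccc(F)cc2)cc1)NCc1ccc(F)cc1` — 12600 nM
compound 2 `O=C(CC1c2ccccc2N=C(SCCCCCN2CCCC2)N1c1ccccc1)NCc1ccc(F)cc1` — 13500 nM

Within the data shown here, in an assay on cells for inhibition of Voltage-dependent T-type calcium channel subunit alpha-1G (Homo sapiens), read by patch clamp (a lower number here means a stronger inhibitor, a higher number a weaker inhibitor), compound 2 gives the highest of the two numbers so far, and its nearest neighbour is compound 1, from which it lies within the scatter. Among the measured compounds shown here, the one step measured, a 1.1-fold higher number from compound 1 to compound 2 (0.03 log units; within the scatter), concerns the aromatic carbon on the other end of the shared core and says nothing about the benzyl amide.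

Compound 3 `O=C(CC1c2ccccc2N=C(SCCCCCN2CCCC2)N1c1ccccc1)NCc1ccccc1` differs from compound 2 by hydrogen in place of fluoro on an aromatic carbon: 4-fluorobenzyl becomes benzyl on the amide side. For the measured compounds named here, no measured step bears directly on this change, and the only step available was flat. The step from compound 2 to compound 3 in this assay is therefore expected to be no change at the digits printed from compound 2 to compound 3 (within the scatter), no change beyond the scatter in either direction. Compound 3 is expected to give 13500 nM, with a range from 6000 nM to 30000 nM.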

Compound 3, half-maximal inhibitory concentration: 77000 nM
For compound 3 the middle estimate is 5.7-fold (0.76 log units) below the measured one, outside the stated range (above it).
By their numbers in this assay, from the lowest: compounds 1 and 2 (each within the scatter of the next); then compound 3.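

In this assay, replacing 4-fluorobenzyl with benzyl on the amide side is not a silent change (a 5.7-fold higher number from compound 2 to compound 3 (0.76 log units; beyond the scatter)), and hydrogen on this aromatic carbon gives the weaker inhibitor. Among these compounds, the only earlier step, made elsewhere on the shared core (a 1.1-fold higher number from compound 1 to compound 2 (0.03 log units; within the scatter)), stayed within the scatter, so this amide-side position is the first place where a change registers, and it does so with the loss of a single fluorine atom. Nothing available accounts for the size of this step.

As far as these compounds go, whether the gain belongs to fluoro itself or would also come with chloro, methyl or methoxy on the same carbon remains open. Also open, from the compounds shown here alone, is whether the step from 4-fluorobenzyl to benzyl keeps its size when the 4-fluorophenyl group of compound 1 is present.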